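Chain length and a halogenated anilide in a nicotinamide phosphoribosyltransferase series

The source may report more compounds than this note shows. Statements on the series, on what has been measured and on what is new or still open speak of the compounds shown alone.

Compound 1 `O=C(/C=C/c1cccnc1)NCCCCCCc1cccc(S(=O)(=O)Nc2ccccc2)c1`: 10.5 nM
Compound 2 `O=C(/C=C/c1cccnc1)NCCCCCCCc1cccc(S(=O)(=O)Nc2ccccc2)c1`: 31.3 nM

In an assay on isolated protein for inhibition of Nicotinamide phosphoribosyltransferase (Homo sapiens), read by WST assay, with stated times of 60 min, 5 min and 30 min, in the presence of a further agent that is not named here (a higher number here means a weaker inhibitor, a lower number a stronger inhibitor), compound 1 gives 10.5 nM, the lowest of the two numbers recorded. Its nearest neighbour is compound 2, which in this assay gives 31.3 nM; the gap between the two values lies beyond the usual scatter of the assay, so compound 1 reads as the stronger inhibitor of the pair. The two compounds share the same core and differ only in the length of the chain joining the amide to the sulfonamide-bearing ring.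

The piece now turns to compound 3 `O=C(/C=C/c1cccnc1)NCCCCCCc1cccc(S(=O)(=O)Nc2ccc(F)c(Cl)c2)c1`, which is not yet measured. It differs from compound 1 in one place: 3-chloro-4-fluorophenyl in place of phenyl on a sulfonamide nitrogen. Among the compounds with values here, no step between measured compounds covers such a change, so the expectation must rest on the value of compound 1 alone. Compound 3 is expected to stay close to compound 1, with a step of a 1.3-fold lower number from compound 1 to compound 3 (0.12 log units; within the scatter) in this assay, not clearly beyond the scatter. Compound 3 is therefore estimated at 8 nM, within a range of 3 nM to 25 nM.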

Compound 3, half-maximal inhibitory concentration: 9.7 nM
The estimate for compound 3 lay 1.2-fold (0.08 log units) below the measured number; the measured number falls inside the stated range.
By their numbers in this assay, from the lowest: compounds 3 and 1 (each within the scatter of the next); then compound 2.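

In this assay, the step from phenyl to 3-chloro-4-fluorophenyl on the sulfonamide nitrogen is a 1.1-fold lower number from compound 1 to compound 3 (0.03 log units; within the scatter) and so leaves compound 3 at 9.7 nM level with compound 1 at 10.5 nM within the scatter. The earlier pair spoke only to the chain joining the amide to the sulfonamide-bearing ring, whereas this step shows that the plain phenyl on this nitrogen is not required for a number of this size, since a ring carrying both a chlorine and a fluorine serves equally well in this assay. Nothing available here bears on why the number holds across this change.

The compounds shown leave open whether the chlorine or the fluorine alone on the phenyl would read the same, and whether a trifluoromethyl group, an amine or a carboxylic acid on this ring would hold the number as well. They also leave open how the 3-chloro-4-fluorophenyl group reads on the longer chain of compound 2 or on a shorter chain than that of compound 1.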